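Lengthening the Chain on a Shared Core: Compound 2 to 3

The source may hold more compounds than are shown below. What is called first, only, known or untested is meant among the compounds shown, and "the series" means these compounds.

Compound 1 `CN(C)C(=O)c1cc2cnc(Nc3ccc(C(=O)NCCCCN=C=S)cc3)nc2n1C1CCCC1`: 55.2%
Compound 2 `CN(C)C(=O)c1cc2cnc(Nc3ccc(C(=O)NCCCCCN=C=S)cc3)nc2n1C1CCCC1`: 50.3%

In a functional assay on NCI-H1299 cells (Homo sapiens) for inhibition, read by CCK-8 assay, with a stated time of 72 h, tested at 1 uM (a higher number here means a stronger effect of the compound at the concentration tested, a lower number a weaker effect), compound 1 gives 55.2%. In the same assay compound 2 gives 50.3%. Of the two numbers, compound 2 stands at the lower one, with compound 1 nearest; the gap is within the scatter: a number 4.9 percentage points lower from compound 1 to compound 2 (within the scatter).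

Compound 3 `CN(C)C(=O)c1cc2cnc(Nc3ccc(C(=O)NCCCCCCCN=C=S)cc3)nc2n1C1CCCC1` differs from compound 2 in one place: a group of 5 heavy atoms (3 carbon, 1 nitrogen, 1 sulfur; no ring) in place of a group of 3 heavy atoms (1 carbon, 1 nitrogen, 1 sulfur; no ring), on a saturated chain carbon, five bonds along the chain from an amide-type nitrogen. Going by the values given here, only one measured step bears on this change, the step of a number 4.9 percentage points lower from compound 1 to compound 2 (within the scatter), which is the same kind of chain extension one bond shorter along the chain and stayed within the scatter. The extension in compound 3 is somewhat larger, so a step no larger than the scatter is expected, if anything slightly downward. Compound 3 is therefore estimated at 45% in this assay, with a range from 30% to 60%, which means an expected step of a number 5.3 percentage points lower from compound 2 to compound 3 (within the scatter).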

Compound 3, a percentage reported as inhibition, at one concentration (the size of the read-out at that concentration, not a potency): 75.7%
Estimate against measurement, compound 3: 30.7 percentage points below; the whole stated range lies below it.
By their numbers in this assay, from the lowest: compounds 2 and 1 (each within the scatter of the next); then compound 3.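

In this assay, the chain extension at this position gives a number 25.4 percentage points higher from compound 2 to compound 3 (beyond the scatter), and against the shortest chain shown it gives a number 20.5 percentage points higher from compound 1 to compound 3 (beyond the scatter). The earlier step, a number 4.9 percentage points lower from compound 1 to compound 2 (within the scatter), had shown no separation, so these three compounds show that chain length at this position can change the read-out, though not evenly from one compound to the next. No evidence available here accounts for this rise.

The compounds shown leave open whether a still longer chain would extend the rise or reverse it, and how chains of intermediate length between those of compound 2 and compound 3 would read. They also leave open whether the rise depends on the isothiocyanate at the chain end, since all three carry it and none has, for example, an amine there instead.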